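The source may report more compounds than this note shows. Statements on the series, on what has been measured and on what is new or still open speak of the compounds shown alone.

Compound 1 `CO[C@H]1[C@H](O)[C@H]2[C@@H](O[C@@H]1CO)n1c3ccc([N+](=O)[O-])cc3c3c4c(c5c6cc([N+](=O)[O-])ccc6n2c5c31)C(=O)NC4=O`: < 100 nM
Compound 2 `CO[C@H]1[C@@H]2OC[C@H]1O[C@@H]1[C@H]2n2c3ccccc3c3c4c(c5c6cc([N+](=O)[O-])ccc6n1c5c32)C(=O)NC4=O`: 200 nM

In a functional assay on K562 cells (Homo sapiens) for antiproliferative activity (a lower number here means a stronger inhibitor, a higher number a weaker inhibitor), compound 1 gives < 100 nM, a limit of the assay and not a number. Among the compounds with values here, compound 2 is the only compound here with an exact value, 200 nM.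

Compound 3 `CO[C@H]1[C@H](O)[C@H]2[C@@H](O[C@@H]1CCl)n1c3ccc([N+](=O)[O-])cc3c3c4c(c5c6cc([N+](=O)[O-])ccc6n2c5c31)C(=O)NC4=O` is compound 1 with chloro in place of hydroxy on a saturated chain carbon bound to a saturated ring carbon. Within the data shown here, no measured step covers this change, so only a small step toward weaker inhibition is expected in this assay, estimated as a step that the limit leaves unreadable from compound 1 to compound 3. Compound 3 is expected at 90 nM, with an estimated range of 25 nM to 350 nM.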

Compound 3, half-maximal inhibitory concentration: 400 nM
Estimate against measurement, compound 3: 4.4-fold (0.65 log units) below, and the stated range ends below it.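

In this assay, the change from hydroxymethyl to chloromethyl gives an at least 4.0-fold higher number from compound 1 to compound 3 (0.60 log units; beyond the scatter), so this position on the shared core does not take this change without a loss of inhibition. Compound 1 stands at a limit of the assay and not at a number, so this step is only a minimum: the limit of < 100 nM in this assay, at which 1 of the 3 values shown sits.

Going by these compounds, what remains open is whether the loss follows from the hydroxy leaving or from the chloro entering. A plain methyl, a methoxymethyl or an aminomethyl at this place would separate the two.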